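Chloro for ethyl on the pyrimidine of a GIP receptor agonist

The source may hold more compounds than are shown below. What is called first, only, known or untested is meant among the compounds shown, and "the series" means these compounds.

Among the compounds with values here, compound 1, `CCc1cnc(N2CCC(c3coc4c(N5CCc6cc(S(C)(=O)=O)ccc65)ncnc34)CC2)nc1`, is the only compound in this set with a numerical result. In a functional assay on cells for agonist activity at Glucose-dependent insulinotropic receptor (Homo sapiens), read by a luciferase reporter, with a stated time of 4 h (on this read-out lower numbers stand for an effect already at smaller amounts and higher numbers for an effect only at larger amounts of compound), compound 1 gives 41 nM. The companion compound 2, `CC(C)(C)OC(=O)N1CCC(c2coc3c(N4c5ccc(S(C)(=O)=O)cc5CC4(C)C)ncnc23)CC1`, has no numerical result. In this assay, within the data shown here, compound 2 gives "not active" (no number reported), with no number behind that word, so compound 1 stands alone on the scale and no step between measured compounds can be drawn from these two.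

The unmeasured compound 3, `CS(=O)(=O)c1ccc2c(c1)CCN2c1ncnc2c(C3CCN(c4ncc(Cl)cn4)CC3)coc12`, differs from compound 1 in one place: chloro in place of ethyl on an aromatic carbon. The shared core and the rest of the molecule are unchanged.

With no measured step of this kind in the set, the expectation for compound 3 rests on the size of the exchange alone, a two-carbon chain for a single chlorine at the same aromatic carbon. Because compound 1 gives 41 nM, compound 3 is expected to land close to it, with a step from compound 1 to compound 3 of a 1.2-fold higher number from compound 1 to compound 3 (0.09 log units; within the scatter), which is within the usual scatter rather than a real shift in either direction. Compound 3 is therefore estimated at 50 nM in this assay, within a range of 18 nM to 140 nM.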

Compound 3, half-maximal effective concentration: 42 nM
The estimate for compound 3 lay 1.2-fold (0.08 log units) above the measured number; low and high end bracket the measured number.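

In this assay, within the data shown here, the exchange of 5-ethylpyrimidin-2-yl for 5-chloropyrimidin-2-yl gives a 1.0-fold higher number from compound 1 to compound 3 (0.01 log units; within the scatter) and so provides the first measured step at this position, one that stays within the usual scatter. This aromatic carbon, two atoms from the ring nitrogen and para to a large group, can therefore carry either ethyl with its 2 heavy atoms or chloro with its 1 heavy atom, with no difference that this read-out can separate on the shared core of compound 1 and compound 3. The data shown offer no independent finding that could explain this match.

Ethyl and chloro are the only two groups compared at this carbon, so it remains open whether a methoxy group, a nitrile, an amine or a longer chain such as butyl would also leave the result within the scatter or would move it clearly. Also open, on these data alone, is whether a bare hydrogen at this carbon would serve as well, which would show whether the position needs a substituent at all.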